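Relocating a methoxyphenyl group across four related compounds

This account rests on a few compounds, and the source may have more. Where it says the series, first, only, none or still open, it means among the compounds named here.

Compound 1 `COc1ccc(OCC(=O)N2CCN(C(c3ccc(F)cc3)c3ccc(F)cc3)CC2)cc1` is tested in a functional assay on PC-12 cells (Rattus norvegicus) for cytotoxicity, read by MTT assay, with a stated time of 24 h, tested at 10 uM (a lower number here means a weaker effect, a higher number a stronger effect of the compound at the concentration tested), and gives 80.5%. Compound 3 `COc1ccccc1OCC(=O)N1CCN(C(c2ccc(F)cc2)c2ccc(F)cc2)CC1` carries one change from compound 1, namely (2-methoxyphenyl in place of 4-methoxyphenyl on an oxygen on a saturated carbon), and in this assay compound 3 gives 79.7%, a step of a number 0.8 percentage points lower from compound 1 to compound 3 (within the scatter). Compound 2 `COc1ccc(OCC(=O)N2CCN(C(c3ccc(Br)cc3)c3ccc(Br)cc3)CC2)cc1` differs from compound 1 in a way that is not broken down here, and in this assay compound 2 gives 50.3%, the lowest of the three measured numbers, lying beyond the scatter below both compound 1 and compound 3.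

Compound 4 `COc1ccccc1OCC(=O)N1CCN(C(c2ccc(Br)cc2)c2ccc(Br)cc2)CC1` has not yet been measured. Going by the values given here, it differs from compound 2 by 2-methoxyphenyl in place of 4-methoxyphenyl on an oxygen on a saturated carbon, which is the same change as the one from compound 1 to compound 3, at the same place.

For compound 4 a step of a number 0.3 percentage points lower from compound 2 to compound 4 (within the scatter) is expected in this assay, because the same change gave a number 0.8 percentage points lower from compound 1 to compound 3 (within the scatter). Compound 4 is therefore estimated at 50%, with the likely range running from 38% to 62%. Among the compounds with values here, only two compounds carry this change, so the expectation rests on a single earlier step.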

Compound 4, a percentage reported as activity, at one concentration (the size of the read-out at that concentration, not a potency): 6.67%
Compound 4: the middle estimate sits 43.3 percentage points above what was measured, outside the stated range (below it).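

In this assay, the change from 4-methoxyphenyl to 2-methoxyphenyl on the core of compound 2 gives a number 43.6 percentage points lower from compound 2 to compound 4 (beyond the scatter), so the same swap does not behave alike on the two cores: the same change on two cores in this assay, a number 0.8 percentage points lower (within the scatter) from compound 1 to compound 3 and a number 43.6 percentage points lower (beyond the scatter) from compound 2 to compound 4, 42.8 percentage points apart, beyond the scatter of two such steps This shows that, in these two pairs, the size of the step depends on the core that carries the change, and that a step too small to read on one core says little about the step on the other. It does not show why the two cores part ways, and two pairs cannot tell which behaviour would be the more usual one on a further core.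

The compounds shown leave open how the same swap would behave on a core with chlorine atoms where compound 1 has fluorine and compound 2 has bromine. They also leave open whether an ethoxy group in place of the methoxy group would give steps that differ in the same way between the two cores.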